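The source may report more compounds than this note shows. Statements on the series, on what has been measured and on what is new or still open speak of the compounds shown alone.

Measured in a functional assay on SW-620 cells (Homo sapiens) for cytotoxicity; on this read-out lower numbers stand for stronger inhibition of growth and higher numbers for weaker inhibition of growth:

- compound 1 `CSc1ccc(C2=C(c3ccc(F)c(F)c3)C(=O)N3CCCC3C2)cc1`: 200 nM
- compound 2 `CSc1ccc(C2=C(c3ccc(O)c(O)c3)C(=O)N3CCCC3C2)cc1`: 50000 nM

Compound 2 has the higher of these two numbers, so it is the weaker growth inhibitor. Going by the values given here, the one measured step is a 250-fold higher number from compound 1 to compound 2 (2.40 log units; beyond the scatter). Compound 3 `CSc1ccc(C2=C(c3ccc(C)cc3)C(=O)N3CCCC3C2)cc1` changes the same ring carbon: 4-methylphenyl in place of 3,4-dihydroxyphenyl on a double-bonded ring carbon. Among the compounds with values here, that measured step is the only guide, since it also concerns 3,4-dihydroxyphenyl at this place. Within the data shown here, no compound with 4-methylphenyl has been measured yet, so carrying the step over is an assumption. Removing 3,4-dihydroxyphenyl is therefore expected to give a large fall in the number, landing near compound 1 at 200 nM, though perhaps not quite as low. The expected change is a 100-fold lower number from compound 2 to compound 3 (2.00 log units; beyond the scatter). For compound 3 the estimated value is 500 nM, with an expected range of 100 nM to 3000 nM.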

Compound 3, concentration for 50% growth inhibition: 3000 nM
Estimate against measurement, compound 3: 6.0-fold (0.78 log units) below; the range from low to high includes it.
By their numbers in this assay, from the lowest: compound 1; then compound 3; then compound 2.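

Putting 4-methylphenyl in place of 3,4-dihydroxyphenyl on this double-bonded ring carbon gives a 17-fold lower number from compound 2 to compound 3 (1.22 log units; beyond the scatter) in this assay, so much of the weakness of compound 2 goes away when this group is exchanged. Recovery is only partial, since 4-methylphenyl in place of 3,4-difluorophenyl gives a 15-fold higher number from compound 1 to compound 3 (1.18 log units; beyond the scatter) and compound 3 therefore sits clearly between the other two, showing that this position separates even two groups without the dihydroxy pattern. Nothing available on these compounds accounts for these differences.

As far as these compounds go, whether a plain phenyl ring, or a phenyl ring carrying an amine or a carboxylic acid, would fall nearer compound 1 or compound 2 remains open. So does whether this order of the three groups would hold on a different core.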